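This account rests on a few compounds, and the source may have more. Where it says the series, first, only, none or still open, it means among the compounds named here.

Three compounds have so far been run in an ADME assay on microsomes from liver (Homo sapiens) for metabolic stability, read by LC-MS, with NADPH named in the record, with a stated time of 60 min, tested at 1 uM, in the absence of a further agent; a higher number here means that more of the compound is left, a lower number that less of the compound is left. Compound 1 `COc1cc(-c2c(C)nc3c(N4CC[C@@H](NC(C)=O)C4)cc(C)nn23)ccc1F` reaches a limit of the assay, giving > 95%. Compound 2 `COc1ccc(-c2c(C)nc3c(N4CC[C@@H](NC(=O)OCc5ccccc5)C4)cc(C)nn23)cc1OC` likewise sits at a limit, with > 95%. Compound 3 `COc1ccc(-c2c(C)nc3c(N4CC[C@@H](NS(=O)(=O)c5ccc(C(F)(F)F)cc5)C4)cc(C)nn23)cc1OC` also lies at a limit, at > 95%. Going by the values given here, compound 2 therefore stands where every measured value stands, namely at the limit of > 95% in this assay, at which 3 of the 3 values shown sit, and no step between measured compounds can be drawn from these numbers. Compound 4 `COc1ccc(-c2c(C)nc3c(N4CC[C@@H](n5cc(-c6ccccc6)nn5)C4)cc(C)nn23)cc1OC` has not yet been measured; it differs from compound 2 by 4-phenyl-1H-1,2,3-triazol-1-yl in place of (benzyloxycarbonyl)amino on a saturated ring carbon. Because all three values sit at the limit of > 95% in this assay, at which 3 of the 3 values shown sit, the step of a number at least 3 percentage points lower from compound 2 to compound 4 (that floor lies within the scatter) is expected to be none beyond the scatter, most likely ending at the limit once more. Compound 4 is accordingly estimated at 92%, within a range from 78% to 100%.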

Compound 4, percent of the compound remaining: "unstable" (no number reported)
For compound 4 the study gives words and no number, so the estimate cannot be set against anything.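

Going by these compounds alone, compound 4 is reported in words with no number and compound 2 only as a limit of the assay, so no step between them can be read. The compounds shown leave open how much of compound 4 remains.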